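The source may hold more compounds than are shown below. What is called first, only, known or untested is meant among the compounds shown, and "the series" means these compounds.

Working notes on the series, read in a functional assay on P388 cells (Mus musculus) for antiproliferative activity, with a stated time of 72 h; on this read-out higher numbers stand for an effect only at larger amounts of compound and lower numbers for an effect already at smaller amounts. Compound 1 (`Cc1cn([C@H]2C[C@H](CF)[C@@H](CO)O2)c(=O)[nH]c1=O`) gives > 100 uM, which is a limit of the assay and not a number. Compound 2 (`Cc1cn([C@@H]2O[C@H](CO)[C@@H](CO)[C@@H]2O)c(=O)[nH]c1=O`) gives > 100 uM, also a limit and not a number. The position of compound 2 is therefore known only as a limit, and the evidence so far is the limit of > 100 uM in this assay, at which 2 of the 2 values shown sit.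

The unmeasured compound 3 (`Cc1cn([C@@H]2O[C@H](CO)[C@@H](CF)[C@@H]2O)c(=O)[nH]c1=O`) differs from compound 2 by fluoro in place of hydroxy on a saturated chain carbon bound to a saturated ring carbon. Within the data shown here, no step between measured compounds gives a size for this exchange. In this assay no step beyond the scatter is expected, and no direction can be assigned. This expectation rests on compound 2 at > 100 uM, a limit, and compound 3 is expected most likely to be reported as a limit too. The expected step, taken from that limit as a nominal value, is a number no higher from compound 2 to compound 3 (the limit leaves the size open). For compound 3 the estimated value is 100 uM, with an expected range from 40 uM to 250 uM.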

Compound 3, concentration for half-maximal effect: > 100 uM
Compound 3: only a limit was reported; the forecaster's own chance of this, stated with the estimate: 85%; the middle value lies on the limit itself.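

Among these compounds, compound 3, like compound 1 and compound 2, is reported only as a limit, so no step from compound 1 or compound 2 to compound 3 can be read: the limit of > 100 uM in this assay, at which 3 of the 3 values shown sit.

The compounds shown leave open whether hydroxymethyl to fluoromethyl has any effect in this assay and whether any compound of the series reaches a readable value there.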